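A few compounds are considered here, and "the series" means these few. Any claim that something is new, unique, unknown or untested is made for them only; others in the source may bear on it.

Measured so far, each in an assay on isolated protein for agonist activity at Free fatty acid receptor 1 (Homo sapiens); on this read-out lower numbers stand for an effect already at smaller amounts and higher numbers for an effect only at larger amounts of compound:
compound 1 `CC#CC(CC(=O)O)c1ccc(OCc2ccc3nc(-c4ccc(CC)cc4)cn3c2)cc1` gives 496 nM
compound 2 `CC#CC(CC(=O)O)c1ccc(OCc2ccc3nc(-c4ccccc4)cn3c2)cc1` gives 979 nM
compound 3 `CC#CC(CC(=O)O)c1ccc(OCc2ccc3nc(-c4ccc(F)cc4)cn3c2)cc1` gives 623 nM

Compound 3 holds the second highest of the three numbers. Its nearest neighbour is compound 1, a 1.3-fold higher number from compound 1 to compound 3 (0.10 log units; within the scatter); its furthest is compound 2, a 1.6-fold lower number from compound 2 to compound 3 (0.20 log units; within the scatter). All three values sit inside one band of scatter, so no order among them can be read.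

Compound 4 `CC#CC(CC(=O)O)c1ccc(OCc2ccc3nc(-c4ccc(C)cc4)cn3c2)cc1` has not yet been measured. It differs from compound 3 by methyl in place of fluoro on an aromatic carbon.

Among the compounds with values here, the steps that bear on this change all concern the same aromatic position: a 2.0-fold higher number from compound 1 to compound 2 (0.30 log units; within the scatter), a 1.6-fold lower number from compound 2 to compound 3 (0.20 log units; within the scatter) and a 1.3-fold higher number from compound 1 to compound 3 (0.10 log units; within the scatter). None of them reaches beyond the scatter, whether the group is ethyl, hydrogen or fluoro. A methyl, one carbon and no ring, sits between hydrogen and ethyl in size, and nothing measured gives reason to expect a step beyond the scatter in this assay in either direction.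

Compound 4 is therefore estimated at about 550 nM, with a range of 280 nM to 1100 nM. That amounts to an expected 1.1-fold lower number from compound 3 to compound 4 (0.05 log units; within the scatter), essentially flat.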

Compound 4, half-maximal effective concentration: 507 nM
The estimate for compound 4 lay 1.1-fold (0.04 log units) above the measured number; the range from low to high includes it.
By their numbers in this assay, from the lowest: compounds 1, 4, 3 and 2 (each within the scatter of the next).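

In this assay, the 4-fluorophenyl to 4-methylphenyl change gives a 1.2-fold lower number from compound 3 to compound 4 (0.09 log units; within the scatter), and placing methyl where hydrogen stood gives a 1.9-fold lower number from compound 2 to compound 4 (0.29 log units; within the scatter), so methyl joins fluoro, hydrogen and ethyl without separating from any of them. Shortening the ethyl by one carbon gives a 1.0-fold higher number from compound 1 to compound 4 (0.01 log units; within the scatter), which adds the comparison of the two alkyl groups and shows no readable difference between them; across all four compounds, no pair at this position stands apart beyond the scatter. Nothing at hand offers a reason for this flat picture.

Still open, as far as these compounds go, is whether a longer chain such as butyl, a methoxy, a trifluoromethyl, an amine or a carboxylic acid at this position would move the number beyond the scatter. Also open, from the compounds shown here alone, is whether the same flat picture holds for these four groups on a core changed elsewhere, as all four compounds here share one core.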